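Changing the Phenyl Ring in a Paw Edema Test

The source may hold more compounds than are shown below. What is called first, only, known or untested is meant among the compounds shown, and "the series" means these compounds.

Of the compounds shown here, three have been measured in a functional assay on the whole organism (strain Wistar) for inhibition, with Rattus norvegicus as the target, read by paw edema, with stated times of 30 min and 3 h, at a dose of 0.05 mmol/kg by the oral route; a higher number here means more inhibition at the dose given (going by the name of the read-out), a lower number less inhibition. Compound 1 `CS(=O)(=O)c1ccc(N2N=C(c3ccccc3)CCC2=O)cc1` gives 26.6% in this assay, which places it second highest of the three numbers. Compound 2 `CS(=O)(=O)c1ccc(N2N=C(c3ccc(-c4ccccc4)cc3)CCC2=O)cc1` gives 6.6%, and compound 3 `CS(=O)(=O)c1ccc(N2N=C(c3ccc(Oc4ccccc4)cc3)CCC2=O)cc1` gives 50%. The step of a number 20 percentage points lower from compound 1 to compound 2 (beyond the scatter); the step of a number 23.4 percentage points higher from compound 1 to compound 3 (beyond the scatter). Comparing the two larger groups directly, a number 43.4 percentage points higher from compound 2 to compound 3 (beyond the scatter).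

Compound 4 `Cc1ccc(O)c(C2=NN(c3ccc(S(C)(=O)=O)cc3)C(=O)CC2)c1` has not yet been measured in this assay. It differs from compound 1 in one place: 2-hydroxy-5-methylphenyl in place of phenyl on a carbon with a double bond to nitrogen. The change sits on a carbon with a double bond to nitrogen of a six-membered non-aromatic ring with 2 nitrogen.

Both measured steps from compound 1 add a group to the phenyl, and they run in opposite directions, one modestly down and one modestly up. Neither adds a hydroxy or a methyl, so they bear only loosely on compound 4. Accordingly the expected step is a number 3.4 percentage points higher from compound 1 to compound 4 (within the scatter), with the direction uncertain. Compound 4 is estimated at 30%, with a range from 8% to 55%.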

Compound 4, a percentage reported as inhibition, in the whole organism at one dose (the size of the read-out at that dose, not a potency): 66.6%
For compound 4 the middle estimate is 36.6 percentage points below the measured one; the whole stated range lies below it.
By their numbers in this assay, from the lowest: compound 2; then compound 1; then compound 3; then compound 4.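

In this assay the swap of phenyl for 2-hydroxy-5-methylphenyl gives a number 40 percentage points higher from compound 1 to compound 4 (beyond the scatter) and so shows that a change to this phenyl can bring a large rise, where the two earlier steps from compound 1 were modest, one down and one up. The entering group also brings a hydrogen-bond donor and a hydrogen-bond acceptor that phenyl lacks, but a single compound cannot link either of them to the rise. Nothing available explains the size of this step.

Hydroxy and methyl enter together, so the share of each in the rise stays unknown, and a phenyl carrying only one of them would be needed to separate them. From the compounds shown here alone, it also remains open whether a methoxy or an amine in place of the hydroxy would keep the rise.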